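The compounds below may be only part of what the source reports. "The series", "measured", "known", "first", "only" and "open" are said of these compounds alone.

Measured compounds:
Compound 1 `CN(c1cc2ncc(=O)[nH]c2cc1Nc1nc(-c2ccc(F)cc2)cs1)C1CCCCC1`: 9920 nM
Compound 2 `CN(c1cc2ncc(=O)[nH]c2cc1Nc1nc(-c2ccc(C#N)cc2)cs1)C1CCCCC1`: 18100 nM

In an ADME assay on Huh-7 cells (Homo sapiens) for cytotoxicity (a higher number here means a weaker inhibitor, a lower number a stronger inhibitor), compound 2 gives 18100 nM and compound 1 gives 9920 nM; the two numbers lie within the scatter of each other, so neither compound is set apart. Compound 3 `COc1ccc(-c2csc(Nc3cc4[nH]c(=O)cnc4cc3N(C)C3CCCCC3)n2)cc1` differs from compound 2 by methoxy in place of cyano on an aromatic carbon. Within the data shown here, the only measured step that bears on this change at the same place is a 1.8-fold higher number from compound 1 to compound 2 (0.26 log units; within the scatter), which stayed within the scatter. An exchange of one small group for another on that ring is therefore expected to give no step beyond the scatter, a 1.3-fold lower number from compound 2 to compound 3 (0.11 log units; within the scatter). Compound 3 is estimated at 14000 nM, between 6000 nM and 35000 nM.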

Compound 3, half-maximal inhibitory concentration: 15000 nM
The estimate for compound 3 lay 1.1-fold (0.03 log units) below the measured number; the measured number falls inside the stated range.
By their numbers in this assay, from the lowest: compounds 1, 3 and 2 (each within the scatter of the next).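

In this assay there is a 1.2-fold lower number from compound 2 to compound 3 (0.08 log units; within the scatter) for this change, and a 1.5-fold higher number from compound 1 to compound 3 (0.18 log units; within the scatter) when methoxy takes the place of fluoro instead. Three different small groups on this aromatic carbon, para to a large group, now cannot be told apart, where earlier only two could be compared. Nothing available explains this result. Still open, going by these compounds, is whether an amine, a carboxylic acid or a longer chain at this place would also stay within the scatter. Also open, on these data alone, is whether changes elsewhere on the shared core would move the number further.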